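Aryl triazene series: nitro for bromo, cytotoxicity

The source may report more compounds than this note shows. Statements on the series, on what has been measured and on what is new or still open speak of the compounds shown alone.

Measured so far:
compound 1, `Brc1cccc(/N=N/N2CCCCC2)c1`: > 100000 nM
compound 2, `O=[N+]([O-])c1cccc(/N=N/N2CCCC2)c1`: 42000 nM

In an ADME assay on BHK-21 cells (Mesocricetus auratus) for cytotoxicity, read by MTT assay, with a stated time of 96 h (on this read-out lower numbers stand for higher toxicity in this test and higher numbers for lower toxicity in this test), compound 1 is recorded only as a limit of the assay, > 100000 nM, not as a number. Of the two values shown, that is the one sitting at the limit of > 100000 nM in this assay, at which 1 of the 2 values shown sits. Compound 2 gives 42000 nM in this assay.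

Compound 3 `O=[N+]([O-])c1cccc(/N=N/N2CCCCC2)c1` differs from compound 1 by nitro in place of bromo on an aromatic carbon. Going by the values given here, no measured pair shares this exact change, so its size is not known from the data. Compound 2 carries the same nitro group and sits at 42000 nM in this assay, which is the only anchor for the nitro-bearing end of the step. The expected step from compound 1 to compound 3 is therefore toward lower numbers, of moderate size, an at least 2.0-fold lower number from compound 1 to compound 3 (0.30 log units; that floor lies within the scatter). For compound 3 the estimated value is 50000 nM, with an expected range from 20000 nM to 120000 nM.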

Compound 3, half-maximal cytotoxic concentration: > 100000 nM
Compound 3 gave a limit, no number; the forecaster's own chance of this, stated with the estimate: 40%; at least 2.0-fold (0.30 log units) between middle value and limit.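

Compound 1 and compound 3 both stand as limits in this assay, not as numbers, so no step can be read for nitro in place of bromo: the limit of > 100000 nM in this assay, at which 2 of the 3 values shown sit.

The compounds shown leave open whether this change shifts the value at all.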